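The source may hold more compounds than are shown below. What is called first, only, known or untested is meant among the compounds shown, and "the series" means these compounds.

Measured in an ADME assay on MT4 cells (Homo sapiens) for cytotoxicity, read by MTT assay, with a stated time of 5 days; a lower number here means that less compound is tolerated, a higher number that more compound is tolerated:
compound 1 `N#Cc1ccc(Nc2nccc(OCc3ccccc3F)n2)cc1`, 151000 nM
compound 2 `COc1ccccc1COc1ccnc(Nc2ccc(C#N)cc2)n1`, 8900 nM
compound 3 `COc1cccc(COc2ccnc(Nc3ccc(C#N)cc3)n2)c1`, 118000 nM

Compound 1 gives the highest of the three numbers in this assay; compound 3 sits close to it, the step being a 1.3-fold lower number from compound 1 to compound 3 (0.11 log units; within the scatter), while compound 2 lies far from it, a 17-fold lower number from compound 1 to compound 2 (1.23 log units; beyond the scatter). Compound 4 `N#Cc1ccc(Nc2nccc(OCc3ccccc3C#N)n2)cc1` is not yet measured. It differs from compound 1 as follows: cyano in place of fluoro on an aromatic carbon. Within the data shown here, two measured steps bear on this. The first, a 17-fold lower number from compound 1 to compound 2 (1.23 log units; beyond the scatter), replaced the fluoro on that aromatic carbon and moved the number a long way down. The second, a 13-fold higher number from compound 2 to compound 3 (1.12 log units; beyond the scatter), shows how strongly the number changed when the same group was moved on that phenyl. Among the measured compounds shown here, a change at this carbon has thus once given a large step, but cyano is not methoxy, and no measured pair tells how cyano behaves here. A step of moderate size toward a lower number is expected for compound 4, a 2.5-fold lower number from compound 1 to compound 4 (0.40 log units; beyond the scatter), with wide uncertainty. Compound 4 is estimated at 60000 nM, range 15000 nM to 160000 nM, in this assay.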

Compound 4, half-maximal cytotoxic concentration: 113000 nM
Compound 4: the middle estimate sits 1.9-fold (0.27 log units) below what was measured; measured number inside the range.
By their numbers in this assay, from the lowest: compound 2; then compounds 4, 3 and 1 (each within the scatter of the next).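

In this assay, cyano in place of fluoro on this aromatic carbon, ortho to a large group, stays within the scatter (a 1.3-fold lower number from compound 1 to compound 4 (0.13 log units; within the scatter)), so a replacement at this carbon need not bring the large step seen with methoxy. Among the four compounds, compound 2 alone carries the low number: the step back is large (a 13-fold higher number from compound 2 to compound 4 (1.10 log units; beyond the scatter)), while the 2-cyanophenyl and 3-methoxyphenyl compounds cannot be told apart (a 1.0-fold lower number from compound 3 to compound 4 (0.02 log units; within the scatter)). Nothing available accounts for the behaviour of methoxy at this carbon.

Going by these compounds, it remains open whether an amine, a carboxylic acid or a longer chain on this carbon would stay with compound 1, compound 3 and compound 4 or fall with compound 2. Also open, on these data alone, is how cyano or fluoro would behave at the place the methoxy holds in compound 3.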